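The compounds below may be only part of what the source reports. "The series", "measured", "known", "first", "only" and "open" are said of these compounds alone.

The measured compounds, in a functional assay on HT-29 cells (Homo sapiens) for inhibition, read by MTT assay, with a stated time of 48 h; on this read-out higher numbers stand for weaker inhibition and lower numbers for stronger inhibition:

Compound 1 `CN1CCN(c2ccc(Nc3ncc4c(n3)N(C3CCCC3)CC(=O)N4)nc2)CC1`: 26500 nM
Compound 2 `O=C1CN(C2CCCC2)c2nc(Nc3ccc(N4CCCCC4)cn3)ncc2N1`: 21100 nM
Compound 3 `O=C1CN(C2CCCC2)c2nc(Nc3ccc(N4CCNCC4)cn3)ncc2N1`: the assay reports only a limit, > 30000 nM

Compound 2 stands beside compound 1 with no separation beyond the scatter, as a 1.3-fold lower number from compound 1 to compound 2 (0.10 log units; within the scatter) shows; the third value, that of compound 3, is a limit of the assay and not a number (the limit of > 30000 nM in this assay, at which 1 of the 3 values shown sits). Compound 4 `CN1C(=O)CN(C2CCCC2)c2nc(Nc3ccc(N4CCCCC4)cn3)ncc21` differs from compound 2 by methyl in place of hydrogen on an amide-type nitrogen in a ring. Going by the values given here, none of the measured steps touches this position: a 1.3-fold lower number from compound 1 to compound 2 (0.10 log units; within the scatter) and an at least 1.4-fold higher number from compound 2 to compound 3 (0.15 log units; that floor lies within the scatter) concern the amine attached to the aromatic carbon, and an at least 1.1-fold higher number from compound 1 to compound 3 (0.05 log units; that floor lies within the scatter) the methyl on the ring amine nitrogen, all within the scatter. Among the compounds with values here, with no step on the amide nitrogen to lean on, the account can only expect a step of modest size, in either direction, for compound 4, and the nearby limit of the assay makes a limit-only result a real possibility. The estimated step of a 1.2-fold higher number from compound 2 to compound 4 (0.09 log units; within the scatter) is thus expected to stay close to compound 2. Compound 4 is therefore estimated at 26000 nM, within 9000 nM to 75000 nM.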

Compound 4, half-maximal inhibitory concentration: 12500 nM
For compound 4 the middle estimate is 2.1-fold (0.32 log units) above the measured one; the range from low to high includes it.
By their numbers in this assay, from the lowest: compounds 4, 2 and 1 (each within the scatter of the next, the first and the last beyond it). At a limit, above all of these: compound 3.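

Compound 4 is the first of the compounds shown with a change on the amide-type nitrogen in a ring, and methyl in place of hydrogen there gives a 1.7-fold lower number from compound 2 to compound 4 (0.23 log units; within the scatter) in this assay. On the piperidin-1-yl compounds, this position therefore takes a methyl with no step beyond the scatter, and compound 4 still gives a number in this assay rather than a limit. Nothing measured here gives a reason for this small step.

Open, on these data alone, is whether a larger group on this nitrogen, such as ethyl, benzyl or a longer chain ending in an amine or a carboxylic acid, would move the number beyond the scatter. Also open, as far as these compounds go, is whether methyl at this nitrogen gives a similar step when 4-methylpiperazin-1-yl or piperazin-1-yl stands on the aromatic carbon in place of piperidin-1-yl.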